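The compounds below may be only part of what the source reports. "The series", "measured", "known", "first", "only" and "open" are said of these compounds alone.

Of the compounds shown here, three sharing one core have been measured in a functional assay on CCRF-CEM cells (Homo sapiens) for inhibition, read by sulforhodamine B assay, with a stated time of 48 h, tested at 10 uM; on this read-out lower numbers stand for less inhibition and higher numbers for more inhibition at the one concentration tested (going by the name of the read-out). Compound 1 `c1ccc2c(-c3cn4ccnc4c(-c4ccc5ncn(C6CCCCC6)c5c4)n3)cccc2c1` gives 17.5%; compound 2 `c1cn2cc(-c3ccsc3)nc(-c3ccc4ncn(C5CCCCC5)c4c3)c2n1` gives 29.2%; compound 3 `c1csc(-c2cn3ccnc3c(-c3ccc4ncn(C5CCCCC5)c4c3)n2)c1` gives 46.4%. Compound 2 thus stands second highest of the three, with compound 1 beneath it and compound 3 above it, both gaps beyond the scatter.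

Compound 4 `FC(F)(F)c1cccc(-c2cn3ccnc3c(-c3ccc4ncn(C5CCCCC5)c4c3)n2)c1` has not yet been measured. It differs from compound 2 at one place: 3-(trifluoromethyl)phenyl in place of thiophen-3-yl on an aromatic carbon.

Within the data shown here, no measured step exchanges an aryl group for a trifluoromethyl-bearing phenyl ring, so the comparison rests on the exchanges at the same position: a number 11.7 percentage points higher from compound 1 to compound 2 (beyond the scatter), a number 28.9 percentage points higher from compound 1 to compound 3 (beyond the scatter) and a number 17.2 percentage points higher from compound 2 to compound 3 (beyond the scatter). Each swap of the aryl group at that carbon moved this assay by a modest amount, and the six-membered carbon-only ring of compound 1 sat lowest. A six-membered carbon-only ring entering in compound 4 is therefore expected to give a small downward step, or none beyond the scatter, as a number 5.2 percentage points lower from compound 2 to compound 4 (within the scatter). For compound 4 the estimate is 24%, within 8% to 42%.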

Compound 4, a percentage reported as inhibition, at one concentration (the size of the read-out at that concentration, not a potency): 27.3%
The estimate for compound 4 lay 3.3 percentage points below the measured number; measured number inside the range.
By their numbers in this assay, from the lowest: compounds 1, 4 and 2 (each within the scatter of the next, the first and the last beyond it); then compound 3.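

In this assay, 3-(trifluoromethyl)phenyl in place of thiophen-3-yl on this aromatic carbon gives a number 1.9 percentage points lower from compound 2 to compound 4 (within the scatter), so a six-membered aromatic ring of carbon only need not differ from a five-membered aromatic ring here. Against thiophen-2-yl, the same group gives a number 19.1 percentage points lower from compound 3 to compound 4 (beyond the scatter), while against naphthalen-1-yl it gives a number 9.8 percentage points higher from compound 1 to compound 4 (within the scatter). Thiophen-2-yl thus remains the only aryl group here whose steps to all the others lie beyond the scatter, which the earlier compounds could not show for a substituted phenyl ring.

No evidence is available to explain these numbers. On these data alone, it remains open how an unsubstituted phenyl ring, or a phenyl ring carrying an amine or a carboxylic acid in place of trifluoromethyl, would read at this carbon.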